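The source may report more compounds than this note shows. Statements on the series, on what has been measured and on what is new or still open speak of the compounds shown alone.

In an ADME assay on microsomes from liver (Homo sapiens) for metabolic stability (on this read-out higher numbers stand for fast clearance and lower numbers for slow clearance), compound 1 `Cc1cccnc1N(C(=O)N1CCC(c2ccccc2F)CC1)[C@@H]1CCCNC1` gives < 8 mL.min-1.g-1, which is a limit of the assay and not a number. Going by the values given here, compound 2 `O=C(N1CCN(c2ccccc2)CC1)N(c1nccc2ccccc12)[C@@H]1CCCNC1` gives 13.8 mL.min-1.g-1, the only true number so far, so its standing rests on this single reading. Compound 3 `Cc1ccc2c(N3CCN(C(=O)N(c4nccc5ccccc45)[C@@H]4CCCNC4)CC3)noc2c1` keeps the rest of compound 2 and changes one place, on an amine nitrogen in a ring: a group of 10 heavy atoms (8 carbon, 1 nitrogen, 1 oxygen; one five-membered aromatic ring with 2 hetero atoms, one six-membered aromatic ring of carbon only) in place of a group of 6 heavy atoms (6 carbon; one six-membered aromatic ring of carbon only), on an amine nitrogen in a ring. The phenyl gives way to a group with one five-membered aromatic ring with 2 hetero atoms and one six-membered aromatic ring of carbon only. Among the compounds with values here, no measured pair differs in one place, so the data offer no direct guide to this change. The estimated step of a 1.3-fold higher number from compound 2 to compound 3 (0.12 log units; within the scatter) is a small rise, expected to stay within the usual scatter. For compound 3 the expected clearance is 18 mL.min-1.g-1, with an estimated range of 9 mL.min-1.g-1 to 36 mL.min-1.g-1.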

Compound 3, intrinsic clearance in microsomes in the Homo sapiens assay: 12.9 mL.min-1.g-1
For compound 3 the middle estimate is 1.4-fold (0.14 log units) above the measured one; measured number inside the range.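

Going by these compounds alone, this is the first one-place step, and in the Homo sapiens assay it reads a 1.1-fold lower number from compound 2 to compound 3 (0.03 log units; within the scatter), so the phenyl on the amine nitrogen can give way to the larger group with a five-membered aromatic ring with 2 hetero atoms and a six-membered aromatic ring of carbon only, with clearance staying within the scatter. The larger group also brings 2 hydrogen-bond acceptors to this place, where the phenyl has none. In a physicochemical assay for lipophilicity, using the shake flask method (on this read-out lower numbers stand for lower lipophilicity and higher numbers for higher lipophilicity), compound 2 gives 0.8 and compound 3 gives 1.6. In the physicochemical assay the same change is not silent, so at this position a higher distribution coefficient comes without a step in clearance beyond the scatter: the measured distribution coefficient of compound 2, 0.8, and of compound 3, 1.6, a number 0.80 log units higher (beyond the scatter)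

From the compounds shown here alone, what a small group such as a methyl on this nitrogen, or a carboxylic acid on the phenyl, would do to either read-out stays open. Within the data shown here, in the Homo sapiens assay compound 1 gives < 8 mL.min-1.g-1, a limit of the assay and not a number, and it differs from the others in more than one place, so it offers no step for this position.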